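Swapping 4-Fluorophenyl for 2-Carboxyethyl on Compound 2

The compounds below may be only part of what the source reports. "The series", "measured", "known", "first", "only" and "open" are said of these compounds alone.

Values so far in a functional assay on PC-9 cells (Homo sapiens) for antiproliferative activity, read by MTT assay, with a stated time of 72 h (a lower number here means a stronger inhibitor, a higher number a weaker inhibitor), are these
compound 1 `COc1ccc(Nc2cc(NC(=O)c3ccccc3)ncn2)cc1` gives 660 nM
compound 2 `O=C(Nc1cc(Nc2ccc(Cl)cc2)ncn1)c1ccc(F)cc1` gives 820 nM
compound 3 `CCOC(=O)CCCC(=O)Nc1cc(Nc2cccc(Cl)c2)ncn1` gives > 30000 nM (a limit)

Compound 2 stands level with compound 1, their two values lying within the scatter of each other. Within the data shown here, compound 4 `O=C(O)CCC(=O)Nc1cc(Nc2ccc(Cl)cc2)ncn1` carries 2-carboxyethyl in place of 4-fluorophenyl on a carbonyl carbon and no measured pair shows this change alone. A large loss of potency in this assay is expected, resting on compound 3, an open-chain compound whose > 30000 nM is a limit. The estimated 22-fold higher number from compound 2 to compound 4 (1.34 log units; beyond the scatter) is expected to point toward a weaker inhibitor. Compound 4 is expected at 18000 nM (estimated range 6000 nM to 30000 nM) if a number is reported at all.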

Compound 4, half-maximal inhibitory concentration: 790 nM
The estimate for compound 4 lay 23-fold (1.36 log units) above the measured number, outside the stated range (below it).
By their numbers in this assay, from the lowest: compounds 1, 4 and 2 (each within the scatter of the next). At a limit, above all of these: compound 3.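

In this assay, 2-carboxyethyl in place of 4-fluorophenyl on a carbonyl carbon gives a 1.0-fold lower number from compound 2 to compound 4 (0.02 log units; within the scatter), so this position takes a chain with no ring without a measurable cost. The open-chain compound 3 gives > 30000 nM, which is a limit. Compound 4 shows that an open chain on this carbonyl carbon is not in itself tied to such a limit.

Which of the several differences between compound 3 and compound 4 goes with that limit remains open. So does whether an amine, a longer chain or a simple alkyl group in place of the carboxylic acid would hold the same level.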